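Aromatic group swap from compound 3 to compound 4

The source may report more compounds than this note shows. Statements on the series, on what has been measured and on what is new or still open speak of the compounds shown alone.

In a functional assay on K562 cells (Homo sapiens) for cytotoxicity, read by MTT assay, with a stated time of 72 h (on this read-out higher numbers stand for weaker inhibition and lower numbers for stronger inhibition), three compounds on one shared core have been measured. Compound 1 (`C=C1C(=O)[C@@]23C(=O)OC[C@]4(C(=O)CCC(C)(C)[C@H]4C=O)[C@@H]2CC[C@@H]1[C@H]3OC(C)=O`) gives 1390 nM, compound 2 (`C=C1C(=O)[C@@]23C(=O)OC[C@]4(C(=O)CCC(C)(C)[C@H]4C=O)[C@@H]2CC[C@@H]1[C@H]3OC(=O)c1ccccc1`) gives 1480 nM and compound 3 (`C=C1C(=O)[C@@]23C(=O)OC[C@]4(C(=O)CCC(C)(C)[C@H]4C=O)[C@@H]2CC[C@@H]1[C@H]3OC(=O)c1ccc(C(F)(F)F)cc1`) gives 2820 nM. Compound 3 has the highest number of the three, but only its gap to compound 1 clears the scatter: a 2.0-fold higher number from compound 1 to compound 3 (0.31 log units; beyond the scatter). Against compound 2 the gap does not clear it: a 1.9-fold higher number from compound 2 to compound 3 (0.28 log units; within the scatter). Replacing methyl with phenyl made no real difference: a 1.1-fold higher number from compound 1 to compound 2 (0.03 log units; within the scatter).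

Compound 4 (`C=C1C(=O)[C@@]23C(=O)OC[C@]4(C(=O)CCC(C)(C)[C@H]4C=O)[C@@H]2CC[C@@H]1[C@H]3OC(=O)c1ccccc1F`) changes one place: 2-fluorophenyl in place of 4-(trifluoromethyl)phenyl on a carbonyl carbon. This puts 2-fluorophenyl in place of 4-(trifluoromethyl)phenyl on a carbonyl carbon. For the measured compounds named here, no measured compound carries the 2-fluorophenyl group, so no step speaks to it directly. The nearest evidence is the trifluoromethyl step, a 1.9-fold higher number from compound 2 to compound 3 (0.28 log units; within the scatter), which compound 4 gives up. Compound 2, at 1480 nM, is therefore the closest guide, and the small range of the series argues against a large move. The estimated step is a 1.7-fold lower number from compound 3 to compound 4 (0.22 log units; within the scatter), expected toward a lower number and not beyond the scatter. For compound 4 the estimated value is 1700 nM, with an expected range of 900 nM to 3200 nM.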

Compound 4, half-maximal inhibitory concentration: 2860 nM
Compound 4: the middle estimate sits 1.7-fold (0.23 log units) below what was measured; measured number inside the range.
By their numbers in this assay, from the lowest: compounds 1, 2, 3 and 4 (each within the scatter of the next, the first and the last beyond it).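

In this assay, exchanging 4-(trifluoromethyl)phenyl for 2-fluorophenyl on this carbonyl carbon leaves the read-out unresolved (a 1.0-fold higher number from compound 3 to compound 4 (0.01 log units; within the scatter)), so the two substituted aromatic groups cannot be told apart at this position. The fluoro step on the phenyl group of compound 2 (a 1.9-fold higher number from compound 2 to compound 4 (0.29 log units; within the scatter)) also stays within the scatter, as does the trifluoromethyl step (a 1.9-fold higher number from compound 2 to compound 3 (0.28 log units; within the scatter)), so neither substitution separates clearly from the unsubstituted phenyl group. Compound 4 is nevertheless the second compound, after compound 3, whose gap from the methyl group of compound 1 clears the scatter, though only modestly (1>4 reads a 2.1-fold higher number from compound 1 to compound 4 (0.31 log units; beyond the scatter)), and compound 2 goes against any rule that aromatic groups as a class separate from methyl.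

No supporting evidence is available to explain these small steps.

Still open, from the compounds shown here alone, is whether a group of another kind on this carbonyl carbon, such as an aminomethyl group, a carboxylic acid-bearing chain or a longer alkyl chain, would move the number further than the aromatic groups do, and whether a methoxy group on the phenyl ring would separate from the unsubstituted phenyl group.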